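The compounds below may be only part of what the source reports. "The series", "measured", "known", "first", "only" and "open" are said of these compounds alone.

Measured in a functional assay on MCF7 cells (Homo sapiens) for antiproliferative activity, read by MTT assay, with a stated time of 48 h; a lower number here means a stronger inhibitor, a higher number a weaker inhibitor:
- Compound 1 `CC(=O)OC/C1=C/C[C@](C)(CCC=C(C)C)/C=C/[C@@H](OC(=O)C=C(C)C)[C@](C)(O)/C=C/C1=O`: 4510 nM
- Compound 2 `CC(C)=CCC[C@]1(C)/C=C/[C@@H](OC(=O)C=C(C)C)[C@](C)(O)/C=C/C(=O)/C(CN(C)C)=C\C1`: 690 nM
- Compound 3 `CCN(CC)C/C1=C/C[C@](C)(CCC=C(C)C)/C=C/[C@@H](OC(=O)C=C(C)C)[C@](C)(O)/C=C/C1=O`: 130 nM

Compound 3 has the lowest number of the three. Compound 4 `CC(C)=CCC[C@]1(C)/C=C/[C@@H](OC(=O)C=C(C)C)[C@](C)(O)/C=C/C(=O)/C(CN2CCN(C)CC2)=C\C1` differs from it in one group: 4-methylpiperazin-1-yl in place of diethylamino on a saturated chain carbon bound to a double-bonded ring carbon. This places 4-methylpiperazin-1-yl in place of diethylamino. Among the compounds with values here, the closest evidence is the one step between two amino groups, a 5.3-fold lower number from compound 2 to compound 3 (0.72 log units; beyond the scatter), which is modest. Within the data shown here, the steps away from acetoxy, a 6.5-fold lower number from compound 1 to compound 2 (0.82 log units; beyond the scatter) and a 35-fold lower number from compound 1 to compound 3 (1.54 log units; beyond the scatter), are modest and large, but they show nothing about a ring amine, and no measured compound carries one. A modest step towards a higher number in this assay is therefore expected. The expected change is a 2.7-fold higher number from compound 3 to compound 4 (0.43 log units; beyond the scatter). For compound 4 the estimate is 350 nM, with an expected range of 110 nM to 1200 nM.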

Compound 4, half-maximal inhibitory concentration: 550 nM
Beside the measured number, compound 4's estimate is 1.6-fold (0.20 log units) below it; the measured number falls inside the stated range.
By their numbers in this assay, from the lowest: compound 3; then compounds 4 and 2 (each within the scatter of the next); then compound 1.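

In this assay, compound 4 is the only compound shown with a ring amine on this saturated chain carbon, and 4-methylpiperazin-1-yl does not match diethylamino, with a 4.2-fold higher number from compound 3 to compound 4 (0.63 log units; beyond the scatter). It cannot be told apart from dimethylamino, with a 1.3-fold lower number from compound 2 to compound 4 (0.10 log units; within the scatter), yet it keeps a clear edge over acetoxy, with an 8.2-fold lower number from compound 1 to compound 4 (0.91 log units; beyond the scatter). Nothing measured here accounts for these differences. Still open, as far as these compounds go, is whether piperidine or morpholine would read like 4-methylpiperazin-1-yl, and whether propyl chains on the amine nitrogen would extend the step from dimethylamino to diethylamino.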